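Acetyl to Isopropyl: Expected Effect on NF-kappa-B Inhibition

The source may report more compounds than this note shows. Statements on the series, on what has been measured and on what is new or still open speak of the compounds shown alone.

Three compounds have been measured in an assay on FRT-Jurkat cells for inhibition of nuclear factor NF-kappa-B complex (Homo sapiens), read by flow cytometry, with a stated time of 24 h, tested at 10 uM; on this read-out lower numbers stand for less inhibition and higher numbers for more inhibition at the one concentration tested (going by the name of the read-out):

compound 1 `CC(=O)c1ccc(Nc2ccc3c(c2)C(=O)N(C2CCC(=O)NC2=O)C3=O)cc1`: -2%
compound 2 `CC(C)c1ccc(Nc2cccc3c2C(=O)N(C2CCC(=O)NC2=O)C3=O)cc1`: 19%
compound 3 `CC(=O)c1ccc(Nc2cccc3c2C(=O)N(C2CCC(=O)NC2=O)C3=O)cc1`: 2%

Compound 2 and compound 3 share one core and differ only in the group on the aryl ring: isopropyl in place of acetyl on an aromatic carbon. This change produced a step of a number 17 percentage points higher from compound 3 to compound 2 (beyond the scatter), a shift beyond the usual scatter of repeated measurements.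

Compound 1 and compound 3 are built from the same atoms joined differently; the difference between the two cores is not broken down here. Their values in this assay lie within the scatter of each other, so no order between them is claimed.

Compound 4 `CC(C)c1ccc(Nc2ccc3c(c2)C(=O)N(C2CCC(=O)NC2=O)C3=O)cc1` has not yet been measured. It relates to compound 1 exactly as compound 2 relates to compound 3: isopropyl in place of acetyl on an aromatic carbon. The two place descriptions agree word for word, so this is the same change, made on the other core.

For the measured compounds named here, the expectation for compound 4 rests on the one earlier example: because compound 3 to compound 2 gave a number 17 percentage points higher from compound 3 to compound 2 (beyond the scatter), a step of similar size, a number 16 percentage points higher from compound 1 to compound 4 (beyond the scatter), is estimated from compound 1 to compound 4. The range is kept wide, as a single precedent on a different core is the only support. Compound 4 is expected to give about 14%, with a plausible span from -2% to 30%.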

Compound 4, a percentage reported as inhibition, at one concentration (the size of the read-out at that concentration, not a potency): 11%
Compound 4: the middle estimate sits 3 percentage points above what was measured; low and high end bracket the measured number.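

On the core of compound 1, isopropyl in place of acetyl gave a number 13 percentage points higher from compound 1 to compound 4 (beyond the scatter) in this assay and so moved the read-out the same way as on the core of compound 2. Across this one pair of cores, the change therefore carried over in direction, and the two steps cannot be told apart in size: the same change on two cores in this assay, a number 17 percentage points higher (beyond the scatter) from compound 3 to compound 2 and a number 13 percentage points higher (beyond the scatter) from compound 1 to compound 4, 4 percentage points apart, within the scatter of two such steps

This does not show a rule for the series, as it rests on two matched pairs and one group exchange, each read at a single concentration, so it gives no potency and no reason for the rise; even with isopropyl, compound 4 gives only 11% at that concentration.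

The compounds shown leave open whether the same step would appear on a third core, or how the read-out would respond to other groups in place of acetyl and isopropyl on the aryl ring, such as an amine, a carboxylic acid or a longer alkyl chain. They also leave open how either core would behave across a range of concentrations rather than at the single one tested here.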